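The source may report more compounds than this note shows. Statements on the series, on what has been measured and on what is new or still open speak of the compounds shown alone.

Compound 1 `Cc1ccc2nc([C@H](CC3CCN(C(=O)C(C)C)CC3)N3C(=O)CN(c4ccc(Oc5ccccc5)cc4)C3=O)n(C)c2c1` and compound 2 `CC(=O)N1CCC(C[C@@H](c2nc3ccccc3n2C)N2C(=O)CN(c3ccc(Oc4ccccc4)cc3)C2=O)CC1` share a core and a diphenyl ether arm, but differ in two places at once. In an assay on isolated protein for antagonist activity at Bile acid receptor (Homo sapiens), read by TR-FRET and LanthaScreen (a lower number here means a stronger inhibitor, a higher number a weaker inhibitor), compound 1 gives 35 nM, while in this assay compound 2 gives 740 nM, the highest of the two numbers, a gap that lies beyond the scatter. Because the two compounds differ twice, these numbers alone cannot say how much each change contributes. Compound 3 `CC(C)C(=O)N1CCC(C[C@@H](c2nc3ccccc3n2C)N2C(=O)CN(c3ccc(Oc4ccccc4)cc3)C2=O)CC1` carries just one of those changes over from compound 2: isopropyl in place of methyl on a carbonyl carbon. The number for compound 1, 35 nM, reached with the isopropylcarbonyl already in place, points toward a lower number for compound 3. The expected step is therefore a fall, a 3.0-fold lower number from compound 2 to compound 3 (0.47 log units; beyond the scatter), though smaller than the whole gap between the two measured compounds, as the other difference remains. Compound 3 is expected to give about 250 nM, within a range from 80 nM to 700 nM.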

Compound 3, half-maximal inhibitory concentration: 38 nM
For compound 3 the middle estimate is 6.6-fold (0.82 log units) above the measured one; the whole stated range lies above it.
By their numbers in this assay, from the lowest: compounds 1 and 3 (each within the scatter of the next); then compound 2.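

In this assay, isopropyl in place of methyl on a carbonyl carbon gives a large step, a 19-fold lower number from compound 2 to compound 3 (1.29 log units; beyond the scatter), so this small addition of carbon atoms matters greatly at this position. The other change, hydrogen in place of methyl on an aromatic carbon, gives a 1.1-fold higher number from compound 1 to compound 3 (0.04 log units; within the scatter), so with isopropyl in place, that methyl makes no difference that can be told from the scatter. No measurement shown here explains the size of the step at the carbonyl carbon.

The compounds shown leave open whether potency would hold, rise or fall with a cyclopropyl, a tert-butyl or a longer chain such as n-butyl on that carbonyl carbon. They also leave open how a chlorine or a methoxy group would read on the aromatic carbon.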